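From an open-chain amine to a small ring

The compounds below may be only part of what the source reports. "The series", "measured", "known", "first", "only" and "open" are said of these compounds alone.

Three compounds share a core and differ only in the amine attached to a thiocarbonyl carbon. Compound 1 `CCN(Cc1ccncc1)C(=S)SCc1ccc(C(=O)Nc2ccccc2N)cc1` is tested in a functional assay on MGC-803 cells (Homo sapiens) for antiproliferative activity, read by CCK-8 assay, with a stated time of 72 h, tested at 2 uM (on this read-out higher numbers stand for a stronger effect at the one concentration tested and lower numbers for a weaker effect), and gives 71.6%. Compound 2 `Nc1ccccc1NC(=O)c1ccc(CSC(=S)N2CCN(c3cccnc3)CC2)cc1` gives 27.6% in this assay, and compound 3 `Nc1ccccc1NC(=O)c1ccc(CSC(=S)N2CCN(c3cnccn3)CC2)cc1` gives 27.1%. Compound 1 therefore stands highest of the three, with both other compounds well beyond the scatter below it. Within the data shown here, the one measured step, a number 0.5 percentage points lower from compound 2 to compound 3 (within the scatter), lies within the scatter and shows that swapping one heteroaryl group for another on that amine nitrogen changes little.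

Compound 4 `Nc1ccccc1NC(=O)c1ccc(CSC(=S)N2CCCC2)cc1` is not yet measured. It differs from compound 1 by pyrrolidin-1-yl in place of ethyl((pyridin-4-yl)methyl)amino on a thiocarbonyl carbon. Among the measured compounds shown here, no measured step covers this exact change. What the measurements do show is that the two compounds whose amine is not the ethyl((pyridin-4-yl)methyl)amino of compound 1, compound 2 and compound 3, sit far below it, while a change within that other amine type hardly mattered. On this basis a downward step is expected, and its size, a number 29.6 percentage points lower from compound 1 to compound 4 (beyond the scatter), is a rough estimate. Compound 4 is thus expected to give about 42% in this assay, plausibly anywhere from 18% to 70%.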

Compound 4, a percentage reported as inhibition, at one concentration (the size of the read-out at that concentration, not a potency): 27%
Estimate against measurement, compound 4: 15 percentage points above; the range from low to high includes it.
By their numbers in this assay, from the lowest: compounds 4, 3 and 2 (each within the scatter of the next); then compound 1.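

Closing the open-chain amine into the small pyrrolidin-1-yl ring on a thiocarbonyl carbon, with the ethyl((pyridin-4-yl)methyl)amino group leaving, gives a number 44.6 percentage points lower from compound 1 to compound 4 (beyond the scatter) in this assay and is the first measured step away from the amine of compound 1. Compound 4 carries no pyridine or pyrazine ring, yet its number lies within the scatter of those of compound 2 and compound 3, so among these four compounds the three with a ring amine sit together and only the open-chain amine of compound 1 stands apart. No measured evidence is at hand to explain this step.

This single change removes the open chain and the pyridine ring together, so the compounds shown cannot tell which of the two matters for the drop. A simple open-chain amine without any aromatic ring, such as diethylamino, and an open-chain benzyl(ethyl)amino group, with a plain benzene ring in place of the pyridine, would help to separate the two.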